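The source may hold more compounds than are shown below. What is called first, only, known or untested is meant among the compounds shown, and "the series" means these compounds.

Measured compounds in an ADME assay on HEK293 cells (Homo sapiens) for cytotoxicity, read by MTT assay, with a stated time of 44 h; a lower number here means a stronger inhibitor, a higher number a weaker inhibitor:

compound 1 `Cc1ccc(C2ON=C(c3ccccc3Cl)O2)cc1`: compound 1 gives > 100000 nM, a limit of the assay and not a number.
compound 2 `CCc1ccc(C2ON=C(c3ccccc3Cl)O2)cc1`: compound 2 gives > 100000 nM, again only a limit.
compound 3 `Cc1ccc(C2ON=C(c3cccc(Cl)c3)O2)cc1`: compound 3 gives > 100000 nM, again only a limit.

The step that the two limits leave unreadable from compound 1 to compound 2 is the change (methyl in place of hydrogen on a saturated chain carbon bound to an aromatic carbon). Its size cannot be read, since both ends are limits. The same change leads from compound 3 to compound 4 `CCc1ccc(C2ON=C(c3cccc(Cl)c3)O2)cc1`: methyl in place of hydrogen on a saturated chain carbon bound to an aromatic carbon, at the same place. The difference between the cores of compound 1 and compound 3 is not broken down here. Going by the values given here, every value so far sits at the limit of > 100000 nM in this assay, at which 3 of the 3 values shown sit.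

For compound 4 the expected step is a step that the limit leaves unreadable from compound 3 to compound 4, beside the unreadable earlier step; this rests on (the limit of > 100000 nM in this assay, at which 3 of the 3 values shown sit), at which compound 1, compound 2 and compound 3 all sit. Compound 4 is therefore estimated at 150000 nM, with a range from 60000 nM to 400000 nM, most likely reported only as a limit.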

Compound 4, half-maximal inhibitory concentration: > 100000 nM
Compound 4 was reported as a limit; the forecaster's own chance of this, stated with the estimate: 90%; the middle value lies beyond the limit too.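

No step can be read from compound 3 to compound 4, since both are reported only as limits: the limit of > 100000 nM in this assay, at which 4 of the 4 values shown sit.

The compounds shown leave open whether the methyl to ethyl change, or the difference between the cores of compound 1 and compound 3, has any measurable size in this assay at all.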